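The compounds below may be only part of what the source reports. "The series", "measured", "known", "first", "only" and "open" are said of these compounds alone.

In an ADME assay (liver) for metabolic stability, with Liver microsome (Rattus norvegicus) as the target, using microsomes and NADPH, with a stated time of 30 min, tested at 1 uM (on this read-out higher numbers stand for fast clearance and lower numbers for slow clearance), compound 1 `Cc1csc(-c2cc(C(O)(C(F)(F)F)C(F)(F)F)cnc2N2CCN(S(=O)(=O)c3ccc(N)nc3)CC2)c1` gives 399 mL.min-1.g-1, compound 2 `CS(=O)(=O)Nc1cccc(-c2cc(C(O)(C(F)(F)F)C(F)(F)F)cnc2N2CCN(S(=O)(=O)c3ccc(N)nc3)CC2)c1` gives 81 mL.min-1.g-1 and compound 3 `Nc1ccc(S(=O)(=O)N2CCN(c3ncc(C(O)(C(F)(F)F)C(F)(F)F)cc3-c3cnccc3F)CC2)cn1` gives 22 mL.min-1.g-1. Compound 3 therefore stands lowest of the three, and its steps to both others lie beyond the scatter. For the measured compounds named here, the next compound to be measured, compound 4 `Cc1nc2cc(-c3cc(C(O)(C(F)(F)F)C(F)(F)F)cnc3N3CCN(S(=O)(=O)c4ccc(N)nc4)CC3)ccc2o1`, keeps the shared core and changes only one group, with 2-methyl-1,3-benzoxazol-5-yl in place of 4-fluoropyridin-3-yl on an aromatic carbon.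

Going by the values given here, two measured steps bear on this change, since each swaps the group at this same place: a 3.7-fold lower number from compound 2 to compound 3 (0.57 log units; beyond the scatter) and an 18-fold lower number from compound 1 to compound 3 (1.26 log units; beyond the scatter). Read in reverse, both show that leaving 4-fluoropyridin-3-yl for another group went with a higher number. The step of a 4.9-fold lower number from compound 1 to compound 2 (0.69 log units; beyond the scatter) shows how widely the two other groups differ from each other. Among the compounds with values here, none of the measured compounds carries the entering group, so these steps offer only a rough guide, and the range has to stay wide. A modest rise is expected in this assay, estimated as a 5.5-fold higher number from compound 3 to compound 4 (0.74 log units; beyond the scatter). For compound 4 the estimated value is 120 mL.min-1.g-1, with an expected range from 40 mL.min-1.g-1 to 350 mL.min-1.g-1.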

Compound 4, intrinsic clearance in microsomes: 99 mL.min-1.g-1
Compound 4: the middle estimate sits 1.2-fold (0.08 log units) above what was measured, and the stated range covers the measured number.
By their numbers in this assay, from the lowest: compound 3; then compounds 2 and 4 (each within the scatter of the next); then compound 1.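

At this aromatic carbon of the shared core, this assay now has a fourth group to compare, and 2-methyl-1,3-benzoxazol-5-yl, with its one five-membered and one six-membered aromatic ring, does not share the low number seen with 4-fluoropyridin-3-yl, the step being a 4.5-fold higher number from compound 3 to compound 4 (0.65 log units; beyond the scatter). Against 3-(methanesulfonamido)phenyl the new group cannot be separated, with a 1.2-fold higher number from compound 2 to compound 4 (0.09 log units; within the scatter), so two groups of quite different make-up read alike here. It still stays clear of 4-methylthiophen-2-yl, with a 4.0-fold lower number from compound 1 to compound 4 (0.61 log units; beyond the scatter), so the four groups fall on three levels, with 4-fluoropyridin-3-yl alone at the low end and 4-methylthiophen-2-yl alone at the high end.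

Nothing measured alongside these numbers speaks to what lies behind them. Still open, on these data alone, is how an amine or a carboxylic acid at this same place would read in this assay, and what the methyl in 2-methyl-1,3-benzoxazol-5-yl contributes to the number.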